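Swapping the group on the amine nitrogen of compound 3

The source may hold more compounds than are shown below. What is called first, only, known or untested is meant among the compounds shown, and "the series" means these compounds.

Measured in a functional assay on HeLa cells (Homo sapiens) for inhibition, read by CCK-8 assay, with a stated time of 48 h; on this read-out higher numbers stand for weaker inhibition and lower numbers for stronger inhibition:
- compound 1 `O=[N+]([O-])c1ccc(NC(=S)NCCNS(=O)(=O)c2ccc(-c3ccccc3O[C@H]3CC[C@@H](O)CC3)s2)cc1`: > 20000 nM (a limit of the assay)
- compound 2 `COc1cccc(NC(=O)NCCNS(=O)(=O)c2ccc(-c3ccccc3OCc3ccccc3)s2)c1`: > 50000 nM (a limit of the assay)
- compound 3 `O=[N+]([O-])c1ccc(NC(=S)NCCNS(=O)(=O)c2ccc(-c3ccccc3OCc3ccccc3)s2)cc1`: 7100 nM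

Within the data shown here, compound 3 stands at 7100 nM, the only true number of the three. The values of compound 1 and compound 2 are limits. Compound 4 `Cc1cc(C)cc(NC(=O)NCCNS(=O)(=O)c2ccc(-c3ccccc3OCc3ccccc3)s2)c1` keeps the core of compound 3, and the change is a group of 11 heavy atoms (9 carbon, 1 nitrogen, 1 oxygen; one six-membered aromatic ring of carbon only) in place of a group of 12 heavy atoms (7 carbon, 2 nitrogen, 2 oxygen, 1 sulfur; one six-membered aromatic ring of carbon only), on an amine nitrogen. The entering group is (3,5-dimethylphenyl)carbamoyl, on an amine nitrogen.

The closest guide is an at least 7.0-fold lower number from compound 2 to compound 3 (0.84 log units; beyond the scatter), a change at that same amine nitrogen. Compound 4 resembles compound 2 there, so a move towards weaker inhibition is expected. The other measured step, an at least 2.8-fold lower number from compound 1 to compound 3 (0.44 log units; beyond the scatter), swaps the group on the oxygen, and compound 4 keeps the benzyl of compound 3, so it says little here.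

The expected change is a 4.9-fold higher number from compound 3 to compound 4 (0.69 log units; beyond the scatter), and the assay may well report only a limit. For compound 4 the estimated value is 35000 nM, with an expected range of 12000 nM to 100000 nM.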

Compound 4, half-maximal inhibitory concentration: > 50000 nM
Compound 4: no number, only a limit; the forecaster's own chance of this, stated with the estimate: 60%; at least 1.4-fold (0.15 log units) between middle value and limit.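

Putting (3,5-dimethylphenyl)carbamoyl on the amine nitrogen gives an at least 7.0-fold higher number from compound 3 to compound 4 (0.84 log units; beyond the scatter), so a second aromatic group of this kind, carrying two methyl groups where compound 2 has a methoxy group, also falls short of the group in compound 3. Compound 4 reads > 50000 nM, which is a limit of the assay and not a number. The step from compound 2 to compound 4 cannot be read, because both compounds sit at the same limit: the limit of > 50000 nM in this assay, at which 2 of the 4 values shown sit.

The group leaving compound 3 and the group entering compound 4 differ in more than one feature, so the compounds shown do not tell whether the sulfur or the substituents on the aromatic ring account for the step. From the compounds shown here alone, how an amine or a carboxylic acid on that aromatic ring would read also stays open.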